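A few compounds are considered here, and "the series" means these few. Any claim that something is new, unique, unknown or untested is made for them only; others in the source may bear on it.

Measured so far in a toxicity assay on the whole organism (strain Icem-CET (SPF Caw)) for cytotoxicity, with Mus musculus as the target; a higher number here means that more compound is needed for the effect, a lower number that less compound is needed:
- compound 1, `C/C(C(=O)NC1CC1)=C(/C)c1ccc(Br)cc1`, gives 600 mg/kg
- compound 2, `C/C(C(=O)NC1CC1)=C(/C)c1ccc(Cl)cc1`, gives only a limit of the assay, > 800 mg/kg
- compound 3, `C/C(C(=O)NC1CC1)=C(/C)c1ccc(C)cc1`, gives 300 mg/kg

Compound 3 has the lowest of the two numbers in this assay; its nearest neighbour is compound 1, which stands a 2.0-fold lower number from compound 1 to compound 3 (0.30 log units; within the scatter), a step within the scatter. Compound 2 sits at a limit (the limit of > 800 mg/kg in this assay, at which 1 of the 3 values shown sits), and the step from compound 2 reads an at least 2.6-fold lower number from compound 2 to compound 3 (0.42 log units; beyond the scatter), which is beyond the scatter, while the step of an at least 1.3-fold higher number from compound 1 to compound 2 (0.12 log units; that floor lies within the scatter) stays within it.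

Compound 4, `COc1ccc(/C(C)=C(\C)C(=O)NC2CC2)cc1`, differs from compound 3 by methoxy in place of methyl on an aromatic carbon. Within the data shown here, no measured step swaps methyl for methoxy; the steps that bear on this change are the three swaps of the group on the same aromatic carbon. Those steps show that changing this group moves the number in this assay by at most a modest amount, with both halogens giving higher numbers than the methyl of compound 3. Compound 4 is therefore expected to lie near compound 3 or somewhat above it, a step of a 1.3-fold higher number from compound 3 to compound 4 (0.12 log units; within the scatter). The estimate for compound 4 in this assay is 400 mg/kg, with a range from 200 mg/kg to 900 mg/kg.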

Compound 4, dose for half-maximal effect: 300 mg/kg
For compound 4 the middle estimate is 1.3-fold (0.12 log units) above the measured one; the range from low to high includes it.
By their numbers in this assay, from the lowest: compounds 3, 4 and 1 (each within the scatter of the next). At a limit, above all of these: compound 2.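

Methoxy in place of methyl, on the aromatic carbon para to a large group, brings in an oxygen and a hydrogen-bond acceptor, yet in this assay the step reads no change at the digits printed from compound 3 to compound 4 (within the scatter). Methoxy also lines up with methyl against the halogens: the step from chloro reads an at least 2.6-fold lower number from compound 2 to compound 4 (0.42 log units; beyond the scatter), as a separation beyond the scatter, while the step from bromo reads a 2.0-fold lower number from compound 1 to compound 4 (0.30 log units; within the scatter), so compound 1 goes against any simple split of halogens from the other two groups. The value of compound 2 is a limit and not a number: the limit of > 800 mg/kg in this assay, at which 1 of the 4 values shown sits.

The compounds shown leave open whether an amine, a carboxylic acid or a longer chain such as ethoxy on this aromatic carbon would stay within the scatter of compound 3 in this assay. As far as these compounds go, all four compounds also keep the shared core unchanged, so what a change away from this aromatic carbon, for instance at the amide hydrogen, would do to the number remains open.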